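The source may hold more compounds than are shown below. What is called first, only, known or untested is meant among the compounds shown, and "the series" means these compounds.

Measured compounds:
- compound 1, `COc1cccc(N2CCN(C(=O)C(C)N3C(=O)CCC3=O)CC2)c1`, gives 75% in a functional assay on the whole organism (strain Swiss) with Mus musculus as the target, in the maximal electroshock model, with a stated time of 0.25 h, at a dose of 300 mg/kg by the intraperitoneal route; on this read-out higher numbers stand for a stronger effect at the one dose given and lower numbers for a weaker effect
- compound 2, `CCC(C(=O)N1CCN(c2cccc(OC)c2)CC1)N1C(=O)CCC1=O`, gives 25% in this assay
- compound 3, `CC(C(=O)N1CCN(c2ccc(C(F)(F)F)cc2)CC1)N1C(=O)CCC1=O`, gives 25% in this assay

Compound 1 and compound 2 share a core and differ in one place: methyl in place of hydrogen on a saturated chain carbon, two bonds along the chain from an amide-type nitrogen in a ring and a carbonyl carbon. On this change the read-out moves a number 50 percentage points lower from compound 1 to compound 2 (beyond the scatter). Compound 3 carries a different core, with a trifluoromethyl group on the aryl ring instead of the methoxy group; the difference between the two cores is not broken down here. In this assay compound 3 stands level with compound 2 at the digits given, and both lie well under compound 1.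

Compound 4, `CCC(C(=O)N1CCN(c2ccc(C(F)(F)F)cc2)CC1)N1C(=O)CCC1=O`, has not yet been measured. It differs from compound 3 by methyl in place of hydrogen on a saturated chain carbon, two bonds along the chain from an amide-type nitrogen in a ring and a carbonyl carbon, which is the same change that separates compound 2 from compound 1, made at the same place. Across the compounds shown this change occurs twice in all. In this assay the step from compound 3 to compound 4 is expected to be a number 15 percentage points lower from compound 3 to compound 4 (beyond the scatter), a smaller drop than the earlier one because compound 3 already starts from 25% and the read-out cannot fall past zero. On that basis compound 4 is expected to give about 10%, estimated to lie between 0% and 30%.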

Compound 4, a percentage reported as activity, at one dose (the size of the read-out at that dose, not a potency): 25%
Estimate against measurement, compound 4: 15 percentage points below; the range from low to high includes it.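

In this assay, methyl in place of hydrogen on the saturated chain carbon now reads no change at the digits printed from compound 3 to compound 4 (within the scatter). The same change therefore does not carry over at one fixed size from the core of compound 1 to the core of compound 3: the same change on two cores in this assay, a number 50 percentage points lower (beyond the scatter) from compound 1 to compound 2 and no change at the digits printed (within the scatter) from compound 3 to compound 4, 50 percentage points apart, beyond the scatter of two such steps

This shows that, in these two pairs, the size of the step depends on the core, so a step read on one core is a poor guide to the other. It does not show which part of the cores sets the difference, and two pairs give no rule for the series; the read-out is also taken at a single dose, so neither step is a difference in potency.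

Open, from the compounds shown here alone, is how a longer chain such as propyl at the same saturated chain carbon would read on each of the two cores, and whether the step on the core of compound 3 would stay flat there too. Also open, going by these compounds, is whether the gap between the two steps follows the trifluoromethyl group or the methoxy group on the aryl ring, a question that a chlorine atom on that ring could help to settle.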